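The compounds below may be only part of what the source reports. "The series", "measured", "known", "first", "only" and "open" are said of these compounds alone.

Three compounds share one core and differ only in the ring attached to the amide-type nitrogen. Compound 1 `CCN(CC)CCCNc1nc(-c2ccc(NC(=O)Nc3ccccc3)cc2)nc2c(Cl)c(Cl)sc12` carries a plain ring there, and in a functional assay on NCI-H460 cells (Homo sapiens) for cytotoxicity, read by MTT assay, with a stated time of 72 h (on this read-out higher numbers stand for weaker inhibition and lower numbers for stronger inhibition), compound 1 gives 850 nM. Compound 2 `CCN(CC)CCCNc1nc(-c2ccc(NC(=O)Nc3ccc(F)cc3)cc2)nc2c(Cl)c(Cl)sc12` gives 450 nM in this assay, and compound 3 `CCN(CC)CCCNc1nc(-c2ccc(NC(=O)Nc3ccccc3Cl)cc2)nc2c(Cl)c(Cl)sc12` gives 330 nM. Of these three numbers compound 3 has the lowest, yet only its distance to compound 1 is beyond the scatter: a 2.6-fold lower number from compound 1 to compound 3 (0.41 log units; beyond the scatter), whereas a 1.4-fold lower number from compound 2 to compound 3 (0.13 log units; within the scatter) and a 1.9-fold lower number from compound 1 to compound 2 (0.28 log units; within the scatter).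

Compound 4 `CCN(CC)CCCNc1nc(-c2ccc(NC(=O)Nc3ccc(C)cc3)cc2)nc2c(Cl)c(Cl)sc12` alters that same ring once more: 4-methylphenyl in place of 2-chlorophenyl on an amide-type nitrogen. Among the compounds with values here, no measured step introduces a 4-methylphenyl, so the only guide is that exchanging substituents on this ring has so far moved the numbers little, with one modest step and two inside the scatter. This change is therefore expected to give only a small step, if anything toward a higher number, a 1.4-fold higher number from compound 3 to compound 4 (0.13 log units; within the scatter). Compound 4 is estimated at 450 nM, with a range from 200 nM to 1000 nM.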

Compound 4, half-maximal inhibitory concentration: 1240 nM
Compound 4: the middle estimate sits 2.8-fold (0.44 log units) below what was measured; measured number outside the range, above it.
By their numbers in this assay, from the lowest: compounds 3, 2, 1 and 4 (each within the scatter of the next, the first and the last beyond it).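

Within the data shown here, exchanging one group on this ring can matter more than the earlier compounds suggested: 4-methylphenyl in place of 2-chlorophenyl gives a 3.8-fold higher number from compound 3 to compound 4 (0.57 log units; beyond the scatter) in this assay and is the largest step on this ring so far. Methyl in place of fluoro also moves the number beyond the scatter, giving a 2.8-fold higher number from compound 2 to compound 4 (0.44 log units; beyond the scatter) for this change, whereas methyl in place of hydrogen gives only a 1.5-fold higher number from compound 1 to compound 4 (0.16 log units; within the scatter) and leaves compound 4 indistinguishable from the plain ring. No measured information accounts for these differences.

Compound 3 and compound 4 differ in both the group and its place on the ring, so these two changes cannot be separated here. On these data alone, how this ring would respond to a methoxy group, an amine or a carboxylic acid also remains open.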